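The compounds below may be only part of what the source reports. "The series", "measured", "known", "first", "only" and "open" are said of these compounds alone.

Measured so far:
compound 1, `C=CC(=O)Nc1ccc(Cn2nc(-c3ccc(Oc4ccccc4)cc3)cc2C(=O)O)cc1`: > 60000 nM
compound 2, `C/C=C/C(=O)N1CCCC(n2nc(-c3ccc(Oc4ccccc4)cc3)cc2C(=O)O)C1`: > 60000 nM
compound 3, `C=CC(=O)Nc1ccc(Cn2nc(-c3ccc(Oc4ccccc4)cc3)cc2CO)cc1`: 6800 nM

All three were tested in a functional assay on Z-138 cells (Homo sapiens) for inhibition, read by luminescence and CellTiter-Glo, with a stated time of 72 h; on this read-out lower numbers stand for stronger inhibition and higher numbers for weaker inhibition. For compound 1 the value > 60000 nM is a limit of the assay, not a number. For compound 2 the value > 60000 nM is likewise a limit of the assay, and in this assay it is the only result shown for that compound; (the limit of > 60000 nM in this assay, at which 2 of the 3 values shown sit). Compound 3 gives a number, 6800 nM, in this assay.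

Compound 1 and compound 3 share a core and differ in one place: hydroxymethyl in place of carboxy on an aromatic carbon. This change gives an at least 8.8-fold lower number from compound 1 to compound 3 (0.94 log units; beyond the scatter). How the core of compound 1 differs from the core of compound 2 is not broken down here.

Compound 4, `C/C=C/C(=O)N1CCCC(n2nc(-c3ccc(Oc4ccccc4)cc3)cc2CO)C1`, has not yet been measured in this assay. It relates to compound 2 as compound 3 relates to compound 1, by the same change: hydroxymethyl in place of carboxy on an aromatic carbon. The expectation is that the same change brings a comparable improvement, so compound 4 is estimated to show a step of an at least 3.0-fold lower number from compound 2 to compound 4 (0.47 log units; beyond the scatter), which rests on the measured step of an at least 8.8-fold lower number from compound 1 to compound 3 (0.94 log units; beyond the scatter) and on compound 3 having given 6800 nM. For compound 4 the estimate in this assay is 20000 nM, expected to lie between 6000 nM and 60000 nM, with a real chance that only a limit is reported because compound 2 itself shows only the limit > 60000 nM.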

Compound 4, half-maximal inhibitory concentration: 51100 nM
Estimate against measurement, compound 4: 2.6-fold (0.41 log units) below; the range from low to high includes it.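

In this assay compound 2 gives > 60000 nM, which is a limit of the assay and not a number. The step measured from it is therefore only a floor, an at least 1.1-fold lower number from compound 2 to compound 4 (0.06 log units; that floor lies within the scatter), so on this second core the swap of carboxy for hydroxymethyl is not shown to do more than repeated measurement alone might, even though compound 4 yields a number rather than a limit. The direction seen on the first core is not contradicted, but neither is it confirmed on the second core, and the two steps cannot be compared in size: the same change on two cores in this assay, an at least 8.8-fold lower number (0.94 log units; beyond the scatter) from compound 1 to compound 3 and an at least 1.1-fold lower number (0.06 log units; that floor lies within the scatter) from compound 2 to compound 4; the limit leaves it open whether they differ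

The true strength of both carboxy compounds stays unknown, which means the full size of the change cannot be read on either core: the limit of > 60000 nM in this assay, at which 2 of the 4 values shown sit. The compounds shown also leave open whether the gain belongs to hydroxymethyl in particular, or whether other groups on the same aromatic carbon, such as an amine, a primary amide or a longer chain ending in a hydroxyl, would give a number on both cores.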